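Lengthening the Carbamate Chain of a Selenocyanate

The source may report more compounds than this note shows. Statements on the series, on what has been measured and on what is new or still open speak of the compounds shown alone.

Compound 1 `CCCOC(=O)Nc1ccc([Se]C#N)cc1`: 68800 nM
Compound 2 `CCCCCCOC(=O)Nc1ccc([Se][Se]c2ccc(NC(=O)OCCCCCC)cc2)cc1`: 67300 nM
Compound 3 `Cc1ccc(OC(=O)Nc2ccc([Se][Se]c3ccc(NC(=O)Oc4ccc(C)cc4)cc3)cc2)cc1`: 75600 nM

In a functional assay on CCRF-CEM cells (Homo sapiens) for cytotoxicity, read by MTT assay, with a stated time of 72 h (a higher number here means that more compound is tolerated, a lower number that less compound is tolerated), compound 1 gives 68800 nM. Among the compounds with values here, compound 2 gives 67300 nM and compound 3 gives 75600 nM; all three values lie within the scatter of one another, so no compound stands apart from the rest.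

Compound 4 `CCCCCCOC(=O)Nc1ccc([Se]C#N)cc1` has not yet been measured. It differs from compound 1 in one place: propyl in place of hydrogen on a saturated chain carbon, three bonds along the chain from an oxygen next to a carbonyl group. Within the data shown here, no step between two measured compounds changes just this part of the molecule, so the change itself cannot be read off directly. Since compound 2, which already carries the longer chain, gives 67300 nM, the expected step from compound 1 to compound 4 in this assay is a 1.0-fold higher number from compound 1 to compound 4 (0.01 log units; within the scatter), none beyond the scatter. Compound 4 is estimated at 70000 nM, within 35000 nM to 140000 nM.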

Compound 4, concentration lethal to 50% of the cells: 72700 nM
Beside the measured number, compound 4's estimate is 1.0-fold (0.02 log units) below it; the range from low to high includes it.
By their numbers in this assay, from the lowest: compounds 2, 1, 4 and 3 (each within the scatter of the next).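

In this assay, within the data shown here, this is the first direct comparison at this place on the chain: the step is a 1.1-fold higher number from compound 1 to compound 4 (0.02 log units; within the scatter) and so does not stand out from the usual variation between repeat measurements. Among these selenocyanates, then, replacing the propyl chain of compound 1 with the hexyl chain of compound 4 leaves the cytotoxicity reading indistinguishable. Still open, on these data alone, is whether a longer chain, or an amine or a carboxylic acid at this place, would shift the number beyond the scatter. No measurement here bears on why this change leaves the reading within the scatter.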